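The source may hold more compounds than are shown below. What is called first, only, known or untested is meant among the compounds shown, and "the series" means these compounds.

In an assay on tissue (HeLa cells) for inhibition of Indoleamine 2,3-dioxygenase 1 (Homo sapiens), read by spectrophotometry (a lower number here means a stronger inhibitor, a higher number a weaker inhibitor), compound 2 `OCc1cc2cc(/C(=N\O)Nc3cccc(Cl)c3)ccc2o1` gives 5900 nM, the higher of the two numbers measured; compound 1 `O/N=C(/Nc1cccc(Br)c1)c1ccc2occc2c1` gives 1100 nM, a gap that lies beyond the scatter. Compound 3 `OCc1cc2cc(/C(=N\O)Nc3cccc(Br)c3)ccc2o1` is not yet measured. It differs from compound 2 by bromo in place of chloro on an aromatic carbon. Among the measured compounds shown here, no measured pair shows this exchange on its own, so it is judged on size alone: a small step is expected, if any, and none beyond the scatter. Compound 3 is therefore expected at 4500 nM, within 2000 nM to 10000 nM, a step of a 1.3-fold lower number from compound 2 to compound 3 (0.12 log units; within the scatter).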

Compound 3, half-maximal inhibitory concentration: 1200 nM
Compound 3: middle estimate off by 3.8-fold (0.57 log units), on the high side; the measured number lies below the stated range.
By their numbers in this assay, from the lowest: compounds 1 and 3 (each within the scatter of the next); then compound 2.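

In this assay, the change from 3-chlorophenyl to 3-bromophenyl gives a 4.9-fold lower number from compound 2 to compound 3 (0.69 log units; beyond the scatter), so this one position on the six-membered aromatic ring carries a step beyond the scatter. With bromo in place, hydroxymethyl in place of hydrogen on an aromatic carbon gives a 1.1-fold higher number from compound 1 to compound 3 (0.04 log units; within the scatter), which lies within the scatter, so this exchange shows no readable effect here. Nothing at hand explains either result.

Going by these compounds, it remains open whether the halogen step holds without the hydroxymethyl group. On these data alone, it is also open how iodo or methoxy at the halogen position, or an amine or carboxylic acid in place of hydroxymethyl, would read.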